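Aryl para-substituent swap on the piperazine-linked series

This account rests on a few compounds, and the source may have more. Where it says the series, first, only, none or still open, it means among the compounds named here.

Measured compounds and their values in a functional assay on the whole organism (Abdomen, strain Swiss) for inhibition, with Mus musculus as the target, with stated times of 30 min, 10 min and 5 min, at a dose of 10 mg/kg by the oral route; on this read-out higher numbers stand for a stronger effect at the one dose given and lower numbers for a weaker effect:
- compound 1 `C=Cc1c(CCCC)nn(CCCN2CCN(c3ccc(C)cc3)CC2)c(=O)c1N`: 0%
- compound 2 `C=Cc1c(C)nn(CCCN2CCCN(c3ccc(C)cc3)CC2)c(=O)c1N`: 0%
- compound 3 `Cc1c(C#N)c(-c2ccccc2)nn1CCCN1CCN(c2ccc(F)cc2)CC1`: 9%

The three numbers lie within the usual scatter of one another; compound 3 cannot be told apart from compound 1 or compound 2 on this read-out. Going by the values given here, no step between measured compounds differing in one place is available, so nothing measured indicates how a single change moves this assay.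

Compound 4 `Cc1ccc(N2CCN(CCCn3nc(-c4ccccc4)c(C#N)c3C)CC2)cc1` is not yet measured. It differs from compound 3 by methyl in place of fluoro on an aromatic carbon. Among the compounds with values here, nothing in the measured set speaks for this change; the only guide is that compound 3 gives 9%.

For compound 4 a step of a number 4 percentage points lower from compound 3 to compound 4 (within the scatter) is expected, no larger than the scatter. Compound 4 is estimated at 5%, within 0% to 20%.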

Compound 4, a percentage reported as inhibition, in the whole organism at one dose (the size of the read-out at that dose, not a potency): 0%
For compound 4 the middle estimate is 5 percentage points above the measured one; low and high end bracket the measured number.
By their numbers in this assay, from the lowest: compounds 1, 2, 4 and 3 (each within the scatter of the next).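

Going by these compounds alone, the change from 4-fluorophenyl to 4-methylphenyl gives the first one-place step in this assay and it reads a number 9 percentage points lower from compound 3 to compound 4 (within the scatter) on an aromatic carbon para to a large group. On this read-out, methyl and fluoro at this place cannot be told apart. Nothing measured offers a reason for this result.

Going by these compounds, whether another group here, such as an amine, a carboxylic acid or a longer chain, would move this assay beyond the scatter remains open. Also open, on these data alone, is whether any one-place change to the shared core would do so.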